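The source may hold more compounds than are shown below. What is called first, only, known or untested is meant among the compounds shown, and "the series" means these compounds.

Compound 1 `CCCN1CC(=O)N(CCC)c2ncn(Cc3ccccc3)c2C1=O` — 11000 nM
Compound 2 `CC(C)CN1C(=O)CN(C)C(=O)c2[nH]cnc21` — 104000 nM

In an assay for binding affinity to adenosine receptor A1 (Rattus norvegicus), read by radioligand binding (a lower number here means a stronger inhibitor, a higher number a weaker inhibitor), compound 2 gives 104000 nM, the higher of the two numbers, while compound 1 gives 11000 nM, a gap beyond the usual scatter. Compound 3 `CC(C)CN1C(=O)CN(C)C(=O)c2c1ncn2Cc1ccccc1` differs from compound 2 by benzyl in place of hydrogen on an aromatic nitrogen. Among the compounds with values here, no step of exactly this kind has been measured here, so the expectation rests on the two numbers alone. The change is expected to lower the number, by a moderate step of a 5.2-fold lower number from compound 2 to compound 3 (0.72 log units; beyond the scatter), beyond the scatter. Compound 3 is therefore estimated at 20000 nM in this assay, between 5000 nM and 80000 nM.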

Compound 3, inhibition constant: 11300 nM
For compound 3 the middle estimate is 1.8-fold (0.25 log units) above the measured one; the range from low to high includes it.
By their numbers in this assay, from the lowest: compounds 1 and 3 (each within the scatter of the next); then compound 2.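

Placing benzyl on this aromatic nitrogen gives the first measured step at this position: in this assay, the change brings a 9.2-fold lower number from compound 2 to compound 3 (0.96 log units; beyond the scatter). This shows that the position accepts a group of this size and that, on this core, the group strengthens binding beyond the scatter. Nothing measured here accounts for the gain. Still open, going by these compounds, is whether the benzyl ring itself matters, since a plain ethyl group or a longer phenethyl chain on this nitrogen could give a different number. An amine or carboxylic acid on the benzyl ring could also shift it either way.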